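Formamidine oxime ethers: extending the alkoxy chain

A few compounds are considered here, and "the series" means these few. Any claim that something is new, unique, unknown or untested is made for them only; others in the source may bear on it.

Three measured analogues share one core. Compound 1 `CCO/N=C/Nc1cc(Cl)c(CC)c(Cl)c1` carries an ethyl group on the aromatic ring and in a physicochemical assay for lipophilicity, measured as octanol-water partition (on this read-out lower numbers stand for lower lipophilicity and higher numbers for higher lipophilicity), compound 1 gives 4.8. For the measured compounds named here, compound 2 `CCO/N=C/Nc1cc(Cl)c(SCC)c(Cl)c1` gives 4.6, the only one-place step in the set being a number 0.20 log units lower from compound 1 to compound 2 (within the scatter). Compound 3 `C#CCc1c(Cl)cc(N/C=N/OC)cc1Cl` gives 3.3 and stands lowest of the three; compound 2 is the nearest and compound 1 the furthest, both gaps lying beyond the scatter.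

Compound 4 `C#CCc1c(Cl)cc(N/C=N/OCCCl)cc1Cl` is not yet measured. It differs from compound 3 by chloromethyl in place of hydrogen on a saturated chain carbon bound to an oxygen. Going by the values given here, no measured step touches the alkoxy chain: the one step available concerns ethylsulfanyl in place of ethyl on an aromatic carbon and speaks to a different part of the molecule, so it offers no direct guide. What remains is the structural change itself, which adds two heavy atoms with no donors, no acceptors and no charge to the ether chain. On that basis an increase in this assay beyond the scatter is expected for compound 4, of about a number 0.70 log units higher from compound 3 to compound 4 (beyond the scatter). The estimate for compound 4 is 4, within a range from 3.5 to 4.5.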

Compound 4, partition coefficient: 3.7
The estimate for compound 4 lay 0.30 log units above the measured number; the range from low to high includes it.
By their numbers in this assay, from the lowest: compound 3; then compound 4; then compounds 2 and 1 (each within the scatter of the next).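

In this assay the alkoxy chain now has a step of its own: methoxy to 2-chloroethoxy, which is chloromethyl in place of hydrogen on a saturated chain carbon bound to an oxygen, gives a number 0.40 log units higher from compound 3 to compound 4 (beyond the scatter), a modest change that still clears the scatter. For the compounds shown here, the earlier compounds held only a change on an aromatic carbon, ethyl to ethylsulfanyl, which stayed within the scatter, so this is the first one-place change to exceed it and the first at this position. Nothing at hand accounts for the size of this step, and a single pair fixes neither a trend along the chain nor a rule for the position.

As far as these compounds go, the step brings in carbon and chlorine together, so the share of each stays open, and a plain ethoxy chain on the core of compound 3 would separate them. Also open, from the compounds shown here alone, are how the read-out runs with a longer chain such as butoxy or with a terminal amine or carboxylic acid in place of the chlorine, and whether the step carries over to the core of compound 1.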